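Aryl exchange on the ring nitrogen of compound 3

This account rests on a few compounds, and the source may have more. Where it says the series, first, only, none or still open, it means among the compounds named here.

Of the compounds shown here, three have been measured in a functional assay on A549 cells (Homo sapiens) for cytotoxicity, read by MTT assay, with a stated time of 48 h; a lower number here means a stronger inhibitor, a higher number a weaker inhibitor. For the measured compounds named here, compound 1 `CC(C)=CCC/C(C)=C/CC/C(C)=C/CC[C@@H]1[C@@]2(C)CC/C(=N\OCc3cn(-c4ccc(Cl)cc4)nn3)C(C)(C)[C@@H]2CC[C@@]1(C)O` gives 12300 nM and compound 2 `CC(C)=CCC/C(C)=C/CC/C(C)=C/CC[C@@H]1[C@@]2(C)CC/C(=N\OCc3cn(-c4ccncc4)nn3)C(C)(C)[C@@H]2CC[C@@]1(C)O` gives 13000 nM; the single one-point step between measured compounds, a 1.1-fold higher number from compound 1 to compound 2 (0.02 log units; within the scatter), stays within the scatter. Compound 3 `CC(C)=CCC/C(C)=C/CC/C(C)=C/CC[C@@H]1[C@@]2(C)C/C(=C\c3ccc(OCc4cn(-c5ccccc5)nn4)cc3)C(=O)C(C)(C)[C@@H]2CC[C@@]1(C)O`, which carries a different arrangement on the shared core, gives 100000 nM, the highest of the three numbers; its nearest neighbour is compound 2, and both compound 2 and compound 1 sit below it by margins beyond the scatter.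

Compound 4 `CC(C)=CCC/C(C)=C/CC/C(C)=C/CC[C@@H]1[C@@]2(C)C/C(=C\c3ccc(OCc4cn(-c5c(Cl)cc([N+](=O)[O-])cc5Cl)nn4)cc3)C(=O)C(C)(C)[C@@H]2CC[C@@]1(C)O` differs from compound 3 in one place: 2,6-dichloro-4-nitrophenyl in place of phenyl on an aromatic nitrogen. Going by the values given here, the only measured step that touches the group on an aromatic nitrogen of this kind is the one from compound 1 to compound 2, and that lay within the scatter; no step to a 2,6-dichloro-4-nitrophenyl group has been measured. On that basis the expected step for compound 4 in this assay is a 1.1-fold lower number from compound 3 to compound 4 (0.05 log units; within the scatter), none beyond the scatter. Compound 4 is therefore estimated at 90000 nM, with a range from 35000 nM to 200000 nM. Compound 3 already stands at 100000 nM, the highest of the three measured numbers, and compound 4 is expected to stand near it.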

Compound 4, half-maximal inhibitory concentration: 34700 nM
Beside the measured number, compound 4's estimate is 2.6-fold (0.41 log units) above it, and the stated range ends above it.
By their numbers in this assay, from the lowest: compounds 1 and 2 (each within the scatter of the next); then compound 4; then compound 3.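

In this assay, for the compounds shown here, the group on the aromatic nitrogen does register on the shared core of compound 3: 2,6-dichloro-4-nitrophenyl in place of phenyl gives a 2.9-fold lower number from compound 3 to compound 4 (0.46 log units; beyond the scatter), whereas the only earlier exchange at this kind of position, a 1.1-fold higher number from compound 1 to compound 2 (0.02 log units; within the scatter), stayed within the scatter. The larger group, with 11 heavy atoms against 6 and 2 hydrogen-bond acceptors against 0, goes with a lower number, so this position accepts substantial added size in this series without a rise in the number. No available measurement bears on why the number falls.

From the compounds shown here alone, the two chlorines and the nitro group enter together, so the share of each in the step stays open. Equally open, going by these compounds, is how a 4-aminophenyl or 4-carboxyphenyl group on the same nitrogen would compare with phenyl and with 2,6-dichloro-4-nitrophenyl.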